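A few compounds are considered here, and "the series" means these few. Any claim that something is new, unique, unknown or untested is made for them only; others in the source may bear on it.

Working notes on the series in an assay for inhibition of Rho-associated protein kinase 1 (Homo sapiens), read by TR-FRET, with stated times of 5 min and 2 h; on this read-out lower numbers stand for stronger inhibition and higher numbers for weaker inhibition.

Two compounds carry a measured number. Compound 1 `Cc1n[nH]c(C)c1-c1cc2c(s1)C(=O)NC(C)(C)N2C` gives in this assay 2100 nM. Compound 2 `CCCC1(C)NC(=O)c2sc(-c3ccncc3)cc2N1` gives in this assay 33 nM. Compound 1 thus stands at the highest of the two numbers recorded, and its nearest neighbour on the scale, compound 2, sits at a markedly lower number, a gap well beyond the scatter of repeated runs. Going by the values given here, no pair of measured compounds differs in a single place, so no measured single step is available to calibrate the change below.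

Compound 3 `Cc1n[nH]cc1-c1cc2c(s1)C(=O)NC(C)(C)N2C` is the next candidate. It differs from compound 1 by one change, (hydrogen in place of methyl on an aromatic carbon), that is, hydrogen in place of methyl on an aromatic carbon of the five-membered aromatic ring with 2 nitrogen. Among the compounds with values here, no measured step bears on this change. The expectation is a step of modest size, a 1.2-fold higher number from compound 1 to compound 3 (0.08 log units; within the scatter), which may not exceed the scatter in either direction. Compound 3 is accordingly expected to land near 2500 nM, with a range from 800 nM to 8000 nM.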

Compound 3, half-maximal inhibitory concentration: 54 nM
The estimate for compound 3 lay 46-fold (1.67 log units) above the measured number; the measured number lies below the stated range.
By their numbers in this assay, from the lowest: compounds 2 and 3 (each within the scatter of the next); then compound 1.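

In this assay the exchange of methyl for hydrogen on an aromatic carbon of the five-membered aromatic ring with 2 nitrogen gives a 39-fold lower number from compound 1 to compound 3 (1.59 log units; beyond the scatter), so a change of 1 heavy atom at this one place moves the number well beyond the scatter. Going by these compounds alone, this position, next to the ring atom that bears a large group, is therefore a sensitive point on the shared core, with the lower number going with hydrogen and the other methyl on that ring left in place; the earlier compounds, which offered no single-place step, could not show this. No measurement presented here bears on the reason for the size of this step.

The compounds shown leave open whether the number at this position follows the size of the group, since only methyl and hydrogen appear there, and an ethyl group, a chlorine atom or an amine would test this. They also leave open whether the methyl that remains in compound 3 contributes to its number, and whether the same exchange gives a step of similar size on a core carrying a different substitution pattern.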